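The compounds below may be only part of what the source reports. "The series", "measured", "known", "first", "only" and "open" are said of these compounds alone.

Working notes on the cyanoazetidine ether series.

Of the compounds shown here, three have numbers so far. Compound 1 `N#CN1CC(OCc2ccc(-c3cccc(OCc4ccccc4)c3)cc2)C1` gives 1.4 nM in an assay on isolated protein for inhibition of N-acylethanolamine-hydrolyzing acid amidase (Homo sapiens), read by fluorescence, with a stated time of 90 min; on this read-out higher numbers stand for weaker inhibition and lower numbers for stronger inhibition. Compound 2 `COc1cccc(-c2ccc(COC3CN(C#N)C3)cc2)c1OC` gives 0.88 nM in the same assay, and compound 3 `Cc1ccc(-c2ccc(COC3CN(C#N)C3)cc2)cc1` gives 0.46 nM. Compound 3 thus carries the lowest of the three numbers. Against compound 2 the gap lies within the scatter, so no order between those two can be read from the data. Against compound 1 the gap is beyond the scatter, so compound 1 stands as the weaker inhibitor of that pair. Among the compounds with values here, no single-point steps between measured compounds are available here, so the three values stand side by side without a counted step among them.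

Compound 4 `N#CN1CC(OCc2ccc(-c3cccnc3)cc2)C1` has not yet been measured in this assay. Relative to compound 3 the change is pyridin-3-yl in place of 4-methylphenyl on an aromatic carbon. Within the data shown here, nothing among the measured compounds isolates this exchange, so the expectation rests on the structural change alone. A modest move toward weaker inhibition, somewhat beyond the scatter, is expected; the step from compound 3 to compound 4 is estimated at a 6.5-fold higher number from compound 3 to compound 4 (0.81 log units; beyond the scatter). Compound 4 is therefore expected to give about 3 nM, with a range from 0.8 nM to 12 nM.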

Compound 4, half-maximal inhibitory concentration: 12 nM
For compound 4 the middle estimate is 4.0-fold (0.60 log units) below the measured one; the measured number falls inside the stated range.
By their numbers in this assay, from the lowest: compounds 3, 2 and 1 (each within the scatter of the next, the first and the last beyond it); then compound 4.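

In this assay, within the data shown here, the exchange of 4-methylphenyl for pyridin-3-yl gives the first counted step, a 26-fold higher number from compound 3 to compound 4 (1.42 log units; beyond the scatter), a large move toward weaker inhibition. Among these compounds, the earlier compounds offered no single-place comparison, so this is the first direct sign that the group on this aromatic carbon, para to a group of 8 heavy atoms, can strongly change the read-out even when one six-membered aromatic ring is kept in place. The exchange removes the methyl group, places a nitrogen in the ring and adds one hydrogen-bond acceptor, but no measurement bears on why the number rises or on which of these changes matters.

Among the compounds shown here, the single step leaves these changes joined, so the separate contributions of the methyl group and the ring nitrogen remain open; unsubstituted phenyl and 6-methylpyridin-3-yl at this place would divide the step into its two parts. Also open, on these data alone, is whether the position of the ring nitrogen matters, which pyridin-4-yl or pyridin-2-yl in the same place would address.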